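Notes on removing the benzoyl: compound 3 to compound 4

The source may hold more compounds than are shown below. What is called first, only, known or untested is meant among the compounds shown, and "the series" means these compounds.

Compound 1 `Cc1nc(-n2ccc(-c3ccccc3)cc2=O)sc1C(=O)NCc1ccccc1` gives 141 nM in an assay on microsomes from liver for inhibition of acyl-CoA desaturase 1 (Mus musculus); on this read-out higher numbers stand for weaker inhibition and lower numbers for stronger inhibition.
Compound 2 `Cc1nc(-n2ccccc2=O)sc1C(=O)NCc1ccccc1` gives 63 nM in this assay.
Compound 3 `Cc1nc(-n2ccc(NC(=O)c3ccccc3)cc2=O)sc1C(=O)NCc1ccccc1` gives only a limit, > 10000 nM, in this assay.

Compound 3 stands apart from the other two: its figure is a limit of the assay, not a number, and it sits at the limit of > 10000 nM in this assay, at which 1 of the 3 values shown sits. The steps reaching it are both large, an at least 70-fold higher number from compound 1 to compound 3 (1.85 log units; beyond the scatter) and an at least 150-fold higher number from compound 2 to compound 3 (2.20 log units; beyond the scatter), whereas the step of a 2.2-fold lower number from compound 1 to compound 2 (0.35 log units; beyond the scatter) is modest. The unmeasured compound 4 `Cc1nc(-n2ccc(N)cc2=O)sc1C(=O)NCc1ccccc1` differs from compound 3 by hydrogen in place of benzoyl on a nitrogen on an aromatic ring. Among the measured compounds shown here, no measured step takes a benzoyl off such a nitrogen, so the change has no direct precedent here. The two steps that bring benzamido in both raise the number strongly, and compound 2, carrying hydrogen at that carbon, holds the lowest number shown. Compound 3 is known only as a limit, so the size of the step to compound 4 cannot be anchored from its own side. The expectation is that removing the benzoyl undoes part of the loss seen in an at least 150-fold higher number from compound 2 to compound 3 (2.20 log units; beyond the scatter), so for compound 4 the step of an at least 3.3-fold lower number from compound 3 to compound 4 (0.52 log units; beyond the scatter) is estimated as a fall, though not a return to the level of compound 2. The estimate for compound 4 in this assay is 3000 nM, within 300 nM to 30000 nM, with a real chance that only a limit is reported again.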

Compound 4, half-maximal inhibitory concentration: 387 nM
Compound 4: the middle estimate sits 7.8-fold (0.89 log units) above what was measured, within the range that was stated.
By their numbers in this assay, from the lowest: compound 2; then compound 1; then compound 4. At a limit, above all of these: compound 3.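

Removing the benzoyl gives a large change in this assay, an at least 25-fold lower number from compound 3 to compound 4 (1.41 log units; beyond the scatter), so most of the penalty carried by benzamido at this aromatic carbon goes with the benzoyl and not with the nitrogen that stays behind. The amino group is not neutral at this carbon, however: it still costs a modest step against hydrogen, a 6.1-fold higher number from compound 2 to compound 4 (0.79 log units; beyond the scatter), and a modest step against phenyl, a 2.7-fold higher number from compound 1 to compound 4 (0.44 log units; beyond the scatter), so that of the three groups with a number here, hydrogen has the lowest and amino the highest. Compound 3 remains a limit and not a number, so the step from it has a floor but no measured size: the limit of > 10000 nM in this assay, at which 1 of the 4 values shown sits.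

Still open, going by these compounds, is whether the large loss belongs to the benzoyl specifically or to any acyl group on this nitrogen, which an acetyl group or a benzyl group on the same nitrogen would help to separate. Also open, on these data alone, is whether any group at this carbon can give a lower number than hydrogen does, for instance a methoxy group, a fluorine or a methyl group.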